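A Terminal Amino Group on the Nonyl Chain

A few compounds are considered here, and "the series" means these few. Any claim that something is new, unique, unknown or untested is made for them only; others in the source may bear on it.

Compound 1 `NC(=O)[C@H]1OC(n2cnc3c(N)ncnc32)[C@H](O)[C@@H]1O` gives 64 nM in an assay on cell membranes for binding affinity to 2-oxoglutarate receptor 1 (Rattus norvegicus), read by radioligand binding; on this read-out higher numbers stand for weaker inhibition and lower numbers for stronger inhibition. For the measured compounds named here, compound 2 `CCCCCCCCCNC(=O)[C@H]1OC(n2cnc3c(N)ncnc32)[C@H](O)[C@@H]1O` gives 31 nM in this assay, the lower of the two numbers measured so far; the only known step, a 2.1-fold lower number from compound 1 to compound 2 (0.31 log units; beyond the scatter), came from nonyl in place of hydrogen on an amide-type nitrogen. Compound 3 `NCCCCCCCCNC(=O)[C@H]1OC(n2cnc3c(N)ncnc32)[C@H](O)[C@@H]1O` differs from compound 2 by amino in place of methyl on a saturated chain carbon, eight bonds along the chain from an amide-type nitrogen. Going by the values given here, no measured step touches the far end of this chain, so that step offers little guidance, and a change hardly beyond the scatter is expected. For compound 3 the estimate is 40 nM, with a range from 13 nM to 120 nM. This corresponds to an expected step of a 1.3-fold higher number from compound 2 to compound 3 (0.11 log units; within the scatter).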

Compound 3, inhibition constant: 29 nM
Beside the measured number, compound 3's estimate is 1.4-fold (0.14 log units) above it, and the stated range covers the measured number.
By their numbers in this assay, from the lowest: compounds 3 and 2 (each within the scatter of the next); then compound 1.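

In this assay, amino in place of methyl at the far end of the chain gives a 1.1-fold lower number from compound 2 to compound 3 (0.03 log units; within the scatter) and so leaves the number unchanged within the scatter. The 8-aminooctyl group also still gives a 2.2-fold lower number from compound 1 to compound 3 (0.34 log units; beyond the scatter) and thus keeps the modest step seen with nonyl. Nothing available here gives a reason for this result. Still open, as far as these compounds go, is whether a carboxylic acid or a hydroxyl at this chain end would read the same. A shorter or longer chain carrying the amine also remains an open case.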